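The source may report more compounds than this note shows. Statements on the series, on what has been measured and on what is new or still open speak of the compounds shown alone.

Compound 1 `CN(C)C1(COc2cccnc2)CC1`: 95 nM in an assay on brain for displacement of a labelled ligand from Neuronal acetylcholine receptor; alpha4/beta2 (Rattus norvegicus); a higher number here means a weaker inhibitor, a lower number a stronger inhibitor.
Compound 2 `CNC1(COc2ccc(Cl)nc2)CC1`: 13 nM.

Compound 2 holds the lowest of the two numbers in this assay; compound 1 sits above it beyond the scatter, but the two differ in more than one place, so no single change is isolated by them. Compound 3 `CN(C)C1(COc2ccc(Cl)nc2)CC1` carries methyl in place of hydrogen on an amine nitrogen, methyl in place of hydrogen on an amine nitrogen. For the measured compounds named here, no measured pair tests this change alone. The step is expected to be a modest rise, a 3.1-fold higher number from compound 2 to compound 3 (0.49 log units; beyond the scatter), beyond the scatter but not large. For compound 3 the estimate in this assay is 40 nM, with a range from 15 nM to 120 nM.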

Compound 3, inhibition constant: 304 nM
Estimate against measurement, compound 3: 7.6-fold (0.88 log units) below; measured number above the stated range.
By their numbers in this assay, from the lowest: compound 2; then compound 1; then compound 3.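

In this assay, going from methylamino to dimethylamino on the chloro-bearing core is a large loss (a 23-fold higher number from compound 2 to compound 3 (1.37 log units; beyond the scatter)), the first sign that this amine nitrogen is sensitive to one added methyl. With dimethylamino held constant, chloro in place of hydrogen on the aromatic carbon also raises the number, though modestly (a 3.2-fold higher number from compound 1 to compound 3 (0.51 log units; beyond the scatter)). No measurement offered here explains either step.

Going by these compounds, whether the methyl step keeps its size without the chloro remains open. So does the reading of a primary amine or an ethyl group on this nitrogen.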